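A Methoxy for Methyl on Compound 2

The source may hold more compounds than are shown below. What is called first, only, known or untested is meant among the compounds shown, and "the series" means these compounds.

Two compounds have numbers in a functional assay on MCF7 cells (Homo sapiens) for inhibition, read by colorimetric assay and MTT assay, with a stated time of 72 h; on this read-out lower numbers stand for stronger inhibition and higher numbers for weaker inhibition. Compound 1 `C=CCCCCOc1ccccc1-c1cnc(OCCC=C)n1C` gives 8000 nM, while compound 2 `C=CCCCCOc1ccc(C)cc1-c1cnc(OCCC=C)n1C` gives 53000 nM, the higher of the two. Compound 3 `C=CCCCCOc1ccc(OC)cc1-c1cnc(OCCC=C)n1C` is still to be measured. It differs from compound 2 at one place: methoxy in place of methyl on an aromatic carbon. This is methoxy in place of methyl on an aromatic carbon. Going by the values given here, only one measured step bears on the change, a methyl in place of hydrogen on an aromatic carbon, which gave a 6.6-fold higher number from compound 1 to compound 2 (0.82 log units; beyond the scatter). Among the compounds with values here, that step was modest, and no measured compound carries a methoxy, so the data fix neither the size nor the direction of this change. No step beyond the scatter is therefore expected, and the expected step is a 1.5-fold lower number from compound 2 to compound 3 (0.18 log units; within the scatter). For compound 3 the estimated value is 35000 nM, with an expected range of 10000 nM to 100000 nM.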

Compound 3, half-maximal inhibitory concentration: 37000 nM
For compound 3 the middle estimate is 1.1-fold (0.02 log units) below the measured one; low and high end bracket the measured number.
By their numbers in this assay, from the lowest: compound 1; then compounds 3 and 2 (each within the scatter of the next).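

In this assay, methoxy in place of methyl on the aromatic carbon para to the (hex-5-en-1-yl)oxy group gives a 1.4-fold lower number from compound 2 to compound 3 (0.16 log units; within the scatter), so the two groups cannot be told apart at this position. Methoxy in place of hydrogen gives a 4.6-fold higher number from compound 1 to compound 3 (0.67 log units; beyond the scatter), which is the same direction as a 6.6-fold higher number from compound 1 to compound 2 (0.82 log units; beyond the scatter), so two different groups at this carbon now both stand beyond the scatter from the hydrogen of compound 1. Nothing at hand explains why the numbers move this way.

On these data alone, whether any group at this carbon keeps the number of compound 1 remains open, since only methyl and methoxy bear on it. As far as these compounds go, a fluorine, an amine or a carboxylic acid here could fall on either side of compound 1, and the other ring carbons remain untested in these compounds.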